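A few compounds are considered here, and "the series" means these few. Any claim that something is new, unique, unknown or untested is made for them only; others in the source may bear on it.

Of the compounds shown here, two of one shared core have been measured in a functional assay on IMR-32 cells for inhibition of Voltage-dependent N-type calcium channel subunit alpha-1B (Homo sapiens), read by calcium flux; a lower number here means a stronger inhibitor, a higher number a weaker inhibitor. Compound 1 `CC1=NC(C)=C(C(=O)O)C(c2ccsc2)/C1=C(\O)OC/C=C/c1ccccc1` gives 2900 nM. Compound 2 `CC1=NC(C)=C(C(=O)O)C(c2cccc(Cl)c2)/C1=C(\O)OC/C=C/C1CCCCC1` gives 830 nM, the lower of the two numbers, and the gap to compound 1 lies beyond the scatter. Compound 3 `CC1=NC(C)=C(C(=O)O)C(c2cccc(Cl)c2)/C1=C(\O)OC/C=C/c1ccc(C)cc1` differs from compound 2 in one place: 4-methylphenyl in place of cyclohexyl on a double-bonded chain carbon bound to a double-bonded chain carbon. For the measured compounds named here, since no pair measured so far isolates this change, only a modest step is expected in this assay, a 1.4-fold higher number from compound 2 to compound 3 (0.16 log units; within the scatter), and it could fall on either side. Compound 3 is therefore estimated at 1200 nM, within a range from 400 nM to 4000 nM.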

Compound 3, half-maximal inhibitory concentration: 890 nM
Beside the measured number, compound 3's estimate is 1.3-fold (0.13 log units) above it; measured number inside the range.
By their numbers in this assay, from the lowest: compounds 2 and 3 (each within the scatter of the next); then compound 1.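

Exchanging cyclohexyl for 4-methylphenyl gives a 1.1-fold higher number from compound 2 to compound 3 (0.03 log units; within the scatter) in this assay, so on this double-bonded chain carbon, a non-aromatic ring and an aromatic ring carrying one more carbon are not told apart by this read-out. Nothing available explains this match. Still open, going by these compounds, is whether this tolerance extends to groups of another kind, such as an amine or a carboxylic acid on the ring at the chain end. A longer chain before that ring is equally untested in the compounds shown here.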